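The source may report more compounds than this note shows. Statements on the series, on what has been measured and on what is new or still open speak of the compounds shown alone.

Measured in an ADME assay on cells (Hepatocyte, liver, Mus musculus, strain CD-1) for pharmacokinetics, read by LC-MS, tested at 1 uM; a lower number here means slower removal, a higher number faster removal of the compound:
- compound 1 `O=C(NCc1cccnc1)Nc1ccc(S(=O)(=O)N2CCC3(CCNC3)CC2)cc1`: 9.2 mL/min/kg
- compound 2 `CC1CNCCN(S(=O)(=O)c2ccc(NC(=O)NCc3cccnc3)cc2)C1`: 16 mL/min/kg

With only these two numbers, compound 2 cannot be separated from compound 1: the measured step is a 1.7-fold higher number from compound 1 to compound 2 (0.24 log units; within the scatter).

Compound 3 `N[C@H]1CC[C@H](NS(=O)(=O)c2ccc(NC(=O)NCc3cccnc3)cc2)CC1` keeps the shared core and changes the group on the sulfonyl sulfur, where (4-aminocyclohexyl)amino enters and the seven-membered non-aromatic ring leaves: a group of 8 heavy atoms (6 carbon, 2 nitrogen; one six-membered non-aromatic ring of carbon only) in place of a group of 8 heavy atoms (6 carbon, 2 nitrogen; one seven-membered non-aromatic ring with 2 hetero atoms), on a sulfonyl sulfur.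

Going by the values given here, one measured step bears on this change. The step from compound 1 to compound 2 also exchanges the group at this place, and it amounted to a 1.7-fold higher number from compound 1 to compound 2 (0.24 log units; within the scatter). Among the compounds with values here, that is a single comparison, and no measured compound carries a six-membered ring of carbon only on the sulfonyl sulfur, so the support is thin. No shift beyond the scatter is expected in this assay, and neither direction is favoured.

The expected step is a 1.1-fold lower number from compound 2 to compound 3 (0.06 log units; within the scatter).

For compound 3 the estimated value is 14 mL/min/kg, with an expected range of 6 mL/min/kg to 32 mL/min/kg.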

Compound 3, clearance in the Hepatocyte assay: 6.3 mL/min/kg
Compound 3: middle estimate off by 2.2-fold (0.35 log units), on the high side, and the stated range covers the measured number.
By their numbers in the Hepatocyte assay, from the lowest: compounds 3, 1 and 2 (each within the scatter of the next, the first and the last beyond it).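

Going by these compounds alone, in the Hepatocyte assay, compound 3 gives 6.3 mL/min/kg with (4-aminocyclohexyl)amino on the sulfonyl sulfur, the first step at this position that lies beyond the scatter (a 2.5-fold lower number from compound 2 to compound 3 (0.40 log units; beyond the scatter)), whereas the comparison with the group of compound 1, which gives 9.2 mL/min/kg, stays within it (a 1.5-fold lower number from compound 1 to compound 3 (0.16 log units; within the scatter)). The position therefore separates the groups of compound 2 and compound 3, while compound 1 cannot be separated from either of them. In a physicochemical assay for solubility, in phosphate buffer, with a stated time of 24 h, tested at 100 uM (a lower number here means a less soluble compound, a higher number a more soluble compound), compound 2 gives 107000 nM and compound 3 gives 161000 nM; the same exchange stays within the scatter (a 1.5-fold higher number from compound 2 to compound 3 (0.18 log units; within the scatter)), and nothing shown accounts for the step in clearance.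

This single exchange replaces the seven-membered non-aromatic ring with a six-membered ring of carbon only and also raises the hydrogen-bond donor count, so the compounds shown cannot assign the step to either difference or to the two defined stereocentres. As far as these compounds go, it remains open whether the clearance of compound 3 would hold with a hydroxyl or a carboxylic acid in place of the amine of the (4-aminocyclohexyl)amino group.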